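This account rests on a few compounds, and the source may have more. Where it says the series, first, only, none or still open, it means among the compounds named here.

Measured compounds:
compound 1 `CC(=O)Oc1ccc(C(=O)Nc2cc3ccc(OCC4CCN(C)C4)c(C)c3oc2=O)cc1CC=C(C)C` — 1880 nM
compound 2 `CC(C)=CCc1cc(C(=O)Nc2cc3ccc(OCCCNC(C)(C)C)c(C)c3oc2=O)ccc1O` — 950 nM

In a functional assay on MCF7 cells (Homo sapiens) for antiproliferative activity (on this read-out lower numbers stand for stronger inhibition and higher numbers for weaker inhibition), compound 2 gives 950 nM, the smaller of the two numbers; the nearest value is that of compound 1, and the gap between them lies within the usual scatter, so no order between the two is established. Going by the values given here, no pair of measured compounds differs in only one place, so no measured step is available for this series.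

Compound 3 `CC(C)=CCc1cc(C(=O)Nc2cc3ccc(OCCCN[C@@H]4C[C@H]5CC[C@@H]4C5)c(C)c3oc2=O)ccc1O` is not yet measured. It differs from compound 2 as follows: a group of 7 heavy atoms (7 carbon; 2 five-membered non-aromatic rings of carbon only) in place of a group of 4 heavy atoms (4 carbon; no ring), on an amine nitrogen. The rest of the molecule is unchanged.

Among the compounds with values here, with no measured step to lean on, the expectation for compound 3 can rest only on the value of compound 2, 950 nM, and on the change itself. The change is expected to move the number by no more than the scatter, with a slight lean toward a lower value, so the step is estimated as a 1.3-fold lower number from compound 2 to compound 3 (0.10 log units; within the scatter). Compound 3 is therefore expected to give about 750 nM in this assay, with a range from 300 nM to 2200 nM.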

Compound 3, half-maximal inhibitory concentration: 1030 nM
For compound 3 the middle estimate is 1.4-fold (0.14 log units) below the measured one; low and high end bracket the measured number.
By their numbers in this assay, from the lowest: compounds 2, 3 and 1 (each within the scatter of the next).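

The series now has its first measured step, on an amine nitrogen whose other neighbour is a saturated chain carbon: in this assay, a group of 7 heavy atoms with 2 five-membered non-aromatic rings of carbon only in place of tert-butyl gives a 1.1-fold higher number from compound 2 to compound 3 (0.04 log units; within the scatter). Thus, a change from 4 to 7 heavy atoms, with 3 defined stereocentres entering, does not separate the two groups on this read-out, and neither group is established as the better one here. Nothing measured bears on the reason for this result.

From the compounds shown here alone, it remains open whether a methyl group, a plain primary amine or a substituent carrying a hydroxyl or a carboxylic acid on this nitrogen would read differently, and whether another stereoisomer of the entering group would match compound 3. Compound 1 differs from compound 2 and from compound 3 in more than one place, so it cannot show how this change behaves with a different amine side chain or with an acetyl group on the phenol oxygen.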